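Fluoro for Chloro on the Sulfonyl Aryl Ring

The source may hold more compounds than are shown below. What is called first, only, known or untested is meant among the compounds shown, and "the series" means these compounds.

Compound 1 `COc1ccc2ncc(S(=O)(=O)c3ccc(C)c(F)c3)c(N3CCC(C)CC3)c2c1` — 73%
Compound 2 `Cc1ccc2ncc(S(=O)(=O)c3ccc(F)cc3)c(N3CCC(C)CC3)c2c1` — 90%
Compound 3 `Cc1ccc2ncc(S(=O)(=O)c3ccc(C)c(Cl)c3)c(N3CCC(C)CC3)c2c1` — 91%

All three compounds share one core and were tested in an assay on isolated protein for displacement of a labelled ligand from metabotropic glutamate receptor 5 (Homo sapiens), with a stated time of 60 min, tested at 1 uM; on this read-out higher numbers stand for more inhibition at the one concentration tested (going by the name of the read-out) and lower numbers for less inhibition. Compound 3 stands highest of the three numbers, with compound 2 nearest, a number within the scatter, and compound 1 furthest, a number beyond it. Compound 1 carries the 3-fluoro-4-methylphenyl group that compound 4 `Cc1ccc2ncc(S(=O)(=O)c3ccc(C)c(F)c3)c(N3CCC(C)CC3)c2c1` will also carry, but differs from compound 4 elsewhere on the shared core, so it cannot settle the question alone.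

The change from compound 3 to compound 4 is fluoro in place of chloro on an aromatic carbon. Among the measured compounds shown here, the only measured step on this sulfonyl aryl group, a number 1 percentage points higher from compound 2 to compound 3 (within the scatter), is within the scatter, and no measured pair isolates the chloro-to-fluoro exchange itself. On this evidence a small step, if any, is expected. Compound 4 is therefore estimated to give 85%, between 70% and 95%. This estimate means an expected step of a number 6 percentage points lower from compound 3 to compound 4 (within the scatter), within the scatter.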

Compound 4, a percentage reported as inhibition, at one concentration (the size of the read-out at that concentration, not a potency): 91%
The estimate for compound 4 lay 6 percentage points below the measured number; the range from low to high includes it.
By their numbers in this assay, from the lowest: compound 1; then compounds 2, 3 and 4 (each within the scatter of the next).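

In this assay, among the compounds shown here, the first direct reading of this exchange gives no change at the digits printed from compound 3 to compound 4 (within the scatter) and so does not tell fluoro from chloro on this aromatic carbon. The 3-fluoro-4-methylphenyl and 4-fluorophenyl groups also read alike, with a number 1 percentage points higher from compound 2 to compound 4 (within the scatter) on the sulfonyl sulfur, while the change on the other side of the molecule gives a number 18 percentage points higher from compound 1 to compound 4 (beyond the scatter) when methyl replaces methoxy on an aromatic carbon. Nothing shown here explains why the halogen exchange left the number in place or why the methyl for methoxy change moved it.

As far as these compounds go, whether trifluoromethyl, a nitrile or a plain hydrogen in place of the halogen would give a higher, lower or level number remains open. Readings at a single concentration also leave open whether compound 2, compound 3 and compound 4 would differ at any other concentration.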